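Cytotoxicity notes on the series, compound 1 to compound 3

The source may report more compounds than this note shows. Statements on the series, on what has been measured and on what is new or still open speak of the compounds shown alone.

compound 1 `O=C1Nc2ccccc2/C1=N/NC(=S)N1CCCCC1` — > 25000 nM
compound 2 `Cc1ccc(NC(=O)N/N=C2\C(=O)Nc3ccccc32)cc1` — > 25000 nM

In an ADME assay on RD cells (Homo sapiens) for cytotoxicity (a lower number here means that less compound is tolerated, a higher number that more compound is tolerated), compound 1 gives > 25000 nM, which is a limit of the assay rather than a number. Compound 2 likewise sits at a limit, > 25000 nM. Compound 1 thus stands at the limit of > 25000 nM in this assay, at which 2 of the 2 values shown sit, with no number to place it more finely. Compound 3 `CCNC(=S)N/N=C1\C(=O)Nc2ccccc21` differs from compound 1 by ethylamino in place of piperidin-1-yl on a thiocarbonyl carbon. Going by the values given here, no measured pair shows what this change does in this assay; with both values at the limit, no step beyond the scatter is expected, and the estimated step that the limit leaves unreadable from compound 1 to compound 3 is none. Compound 3 is expected to give about 40000 nM, between 20000 nM and 100000 nM, most likely again as a limit only.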

Compound 3, half-maximal cytotoxic concentration: > 25000 nM
Compound 3 gave a limit, no number; the forecaster's own chance of this, stated with the estimate: 80%; the middle value does not contradict the limit.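

No step can be read between compound 1 and compound 3 in this assay, since both give only a limit: the limit of > 25000 nM in this assay, at which 3 of the 3 values shown sit.

The compounds shown leave open whether ethylamino in place of piperidin-1-yl on a thiocarbonyl carbon changes cytotoxicity at all.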